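This account rests on a few compounds, and the source may have more. Where it says the series, first, only, none or still open, it means among the compounds named here.

Three analogues sharing one core have been examined in a functional assay on A549 cells (Homo sapiens) for cytotoxicity, read by MTT assay, with a stated time of 48 h; a lower number here means a stronger inhibitor, a higher number a weaker inhibitor. Compound 1, `COc1cc(-c2nnc3n2NC(c2ccco2)C(C(=O)c2ccccc2F)S3)cc(OC)c1OC`, gives 78700 nM. Compound 2, `COc1cc(-c2nnc3n2NC(c2ccco2)C(C(=O)c2cccs2)S3)cc(OC)c1OC`, gives 78700 nM, and compound 3, `COc1cc(-c2nnc3n2NC(c2cccs2)C(C(=O)c2ccc(C)cc2)S3)cc(OC)c1OC`, gives 12700 nM. Compound 2 therefore stands level with compound 1, the two together giving the highest numbers of the three, while compound 3 sits at a lower number, a gap beyond the scatter; compound 3 differs from compound 2 in more than one place, so its values say nothing specific about any single change.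

The step of interest leads from compound 2 to compound 4, `COc1cc(-c2nnc3n2NC(c2ccco2)C(C(=O)C2CC2)S3)cc(OC)c1OC`. The change is cyclopropyl in place of thiophen-2-yl on a carbonyl carbon. Among the measured compounds shown here, one measured step touches the same carbonyl carbon: no change at the digits printed from compound 1 to compound 2 (within the scatter). For the measured compounds named here, that single swap of one ring for another on the carbonyl left the number unchanged within the scatter, which is the only guidance available for this position. Going by the values given here, no measured step involves a cyclopropyl group at all.

On that basis compound 4 is expected to show a 1.1-fold lower number from compound 2 to compound 4 (0.05 log units; within the scatter), a change that stays within or only slightly beyond the scatter, with the direction uncertain. The estimated value for compound 4 in this assay is 70000 nM, with a range from 25000 nM to 200000 nM.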

Compound 4, half-maximal inhibitory concentration: > 100000 nM
Compound 4 gave a limit, no number (the forecaster's own chance of this, stated with the estimate: 15%); at least 1.4-fold (0.15 log units) between middle value and limit.
By their numbers in this assay, from the lowest: compound 3; then compounds 1 and 2 (each within the scatter of the next). At a limit, above all of these: compound 4.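

In this assay compound 4 gives a limit of the assay and not a number: the limit of > 100000 nM in this assay, at which 1 of the 4 values shown sits. Read against the two aromatic rings, this gives an at least 1.2-fold higher number from compound 2 to compound 4 (0.10 log units; that floor lies within the scatter) and an at least 1.2-fold higher number from compound 1 to compound 4 (0.10 log units; that floor lies within the scatter), and since both floors lie within the scatter, neither step fixes how large the true change is. From the compounds shown here alone, the earlier step had only exchanged one aromatic ring for another on this carbonyl carbon, whereas the non-aromatic cyclopropyl now shows that a smaller ring of carbon only brings no measurable gain in this assay over thiophen-2-yl or 2-fluorophenyl, although the size of any loss remains unknown.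

The compounds shown leave open how far compound 4 really lies from compound 1 and compound 2, and whether a longer alkyl chain, an amine or a carboxylic acid on the same carbonyl carbon would read like cyclopropyl or like the aromatic rings. They also leave open which of its differences accounts for the lower number of compound 3, since it differs from the others in more than one place.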